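The compounds below may be only part of what the source reports. "The series", "measured", "known", "first", "only" and "open" are said of these compounds alone.

Working notes on the series. The set rests on one shared core, varied in the side chain and at one aromatic carbon. Compound 1 `CC(C)(C(=O)Nc1ccc(C(=O)Nc2ccc(F)cc2N)cc1)c1ccccc1` carries a fluoro at that carbon; compound 2 `CC(C)[C@@H](C(=O)Nc1ccc(C(=O)Nc2ccccc2N)cc1)c1ccccc1` carries hydrogen there; compound 3 `CC(C)[C@@H](C(=O)Nc1ccc(C(=O)Nc2ccc(C(F)(F)F)cc2N)cc1)c1ccccc1` carries a trifluoromethyl. In an assay on isolated protein for inhibition of histone deacetylase 5 (Homo sapiens), tested at 1 uM (on this read-out lower numbers stand for less inhibition and higher numbers for more inhibition at the one concentration tested (going by the name of the read-out)), compound 1 gives 0%. In this assay compound 2 gives 9%, and compound 3 gives 0%. Going by the values given here, the only single-place step among the measured compounds is a number 9 percentage points lower from compound 2 to compound 3 (within the scatter), so the trifluoromethyl brings no shift that stands out of the noise. Compound 3 thus sits level with compound 1 at the digits shown, the two together forming the low end of three numbers, and its gap to compound 2 also lies within the scatter.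

The next compound, compound 4 `CC(C)[C@@H](C(=O)Nc1ccc(C(=O)Nc2ccc(F)cc2N)cc1)c1ccccc1`, differs from compound 3 only by fluoro in place of trifluoromethyl on an aromatic carbon. Among the compounds with values here, compound 1 already shows what a fluoro at this carbon gives on a closely related side chain, namely 0%, and every number so far is small. Within the data shown here, no step among the measured compounds reaches beyond the scatter, so for compound 4 no movement beyond the scatter is expected in this assay; the step of a number 2 percentage points higher from compound 3 to compound 4 (within the scatter) is estimated to be essentially flat. Compound 4 is therefore expected to read about 2% in this assay, with a plausible span from 0% to 12%.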

Compound 4, a percentage reported as inhibition, at one concentration (the size of the read-out at that concentration, not a potency): 0%
Compound 4: middle estimate off by 2 percentage points, on the high side; the measured number falls inside the stated range.
By their numbers in this assay, from the lowest: compounds 1, 3, 4 and 2 (each within the scatter of the next).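

At this aromatic carbon, meta to an amino group and para to a large group, fluoro in place of trifluoromethyl gives no change at the digits printed from compound 3 to compound 4 (within the scatter) and fluoro in place of hydrogen gives a number 9 percentage points lower from compound 2 to compound 4 (within the scatter) on the same side chain. Hydrogen, fluoro and trifluoromethyl can now be compared directly on that side chain, and in this assay none of the steps among them lies beyond the scatter. The side-chain change, 2-methyl-1-phenylpropyl in place of 1-methyl-1-phenylethyl on a carbonyl carbon, adds the first single-place comparison away from this aromatic carbon and gives no change at the digits printed from compound 1 to compound 4 (within the scatter) with fluoro held constant, while no separate data offer an explanation for these readings.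

The four compounds therefore leave open whether either varied place can move this read-out at all, since every comparison shown stays within the scatter at one tested concentration. A methoxy or a nitrile at the aromatic carbon, or a side chain bearing an amine or a carboxylic acid in place of the phenyl-bearing chains, remains untested in the compounds shown here and could show whether larger steps exist in this series.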